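The source may report more compounds than this note shows. Statements on the series, on what has been measured and on what is new or still open speak of the compounds shown alone.

Measured in a functional assay on MCF7 cells (Homo sapiens) for cytotoxicity, read by MTT assay, with a stated time of 48 h; a higher number here means a weaker inhibitor, a lower number a stronger inhibitor:
- compound 1 `C#CC1=CC[C@@]2(C)C(=C)CCC[C@]2(C)CC1`: 575000 nM
- compound 2 `C=C1CCC[C@]2(C)CCC(c3cn(-c4ccc(C(C)=O)cc4)nn3)=CC[C@@]12C`: 65400 nM

Compound 2, at 65400 nM, has the lower of the two numbers, and compound 1 sits higher by more than the usual scatter. Compound 3 `C=C1CCC[C@]2(C)CCC(c3cn(-c4ccc(I)cc4)nn3)=CC[C@@]12C` has not yet been measured. It keeps the shared core and changes in one place: iodo in place of acetyl on an aromatic carbon. Put plainly, the acetyl group of compound 2 gives way to an iodo group, so 4-acetylphenyl becomes 4-iodophenyl. Within the data shown here, no measured pair shows what this swap does, so the expectation is tentative. Only a small shift toward a lower number is expected, one that stays within the scatter. The estimate means a 1.3-fold lower number from compound 2 to compound 3 (0.12 log units; within the scatter), an expected change that is modest. The estimated value for compound 3 is 50000 nM, with an expected range from 20000 nM to 125000 nM.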

Compound 3, half-maximal inhibitory concentration: 162000 nM
For compound 3 the middle estimate is 3.2-fold (0.51 log units) below the measured one; measured number outside the range, above it.
By their numbers in this assay, from the lowest: compound 2; then compound 3; then compound 1.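

In this assay, the group on the aromatic ring makes a measurable difference: putting iodo in place of acetyl, on the carbon para to a large group, gives a 2.5-fold higher number from compound 2 to compound 3 (0.39 log units; beyond the scatter), a modest step but one beyond the usual scatter. At this position, then, the single iodine atom does not match the three heavy atoms of the acetyl group, and the 4-acetylphenyl compound keeps the lower number of this pair. Nothing available explains why the number rises, so the step stands as an observation only.

A single pair cannot show whether the acetyl group itself is what favours compound 2, or whether iodo is simply a poor choice here. On these data alone, how an amine, a carboxylic acid or a longer chain would behave at this same place remains open.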